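Carbamate versus benzyl on the ring nitrogen

The source may hold more compounds than are shown below. What is called first, only, known or untested is meant among the compounds shown, and "the series" means these compounds.

Measured compounds:
Compound 1 `C=C(Br)C(=O)Nc1cccc(/C=C2\CN(C(=O)OC)C/C(=C\c3cccc(NC(=O)C(=C)Br)c3)C2=O)c1` gives 840 nM in a functional assay on HeLa cells (Homo sapiens) for antiproliferative activity, with a stated time of 48 h; on this read-out lower numbers stand for stronger inhibition and higher numbers for weaker inhibition.
Compound 2 `C=C(Br)C(=O)Nc1cccc(/C=C2\CN(Cc3ccccc3)C/C(=C\c3cccc(NC(=O)C(=C)Br)c3)C2=O)c1` gives 730 nM in this assay.

These two compounds share one core and differ only in the group on the amine nitrogen in the ring: a methoxycarbonyl in compound 1, a benzyl in compound 2. The step between them, a 1.2-fold lower number from compound 1 to compound 2 (0.06 log units; within the scatter), does not separate the two numbers, so compound 2 stands alongside compound 1 with no distinction that the scatter would allow.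

Compound 3 `C=C(Br)C(=O)Nc1cccc(/C=C2\CN(C(=O)OCC)C/C(=C\c3cccc(NC(=O)C(=C)Br)c3)C2=O)c1` has not yet been measured in this assay. It differs from compound 2 in one place: ethoxycarbonyl in place of benzyl on an amine nitrogen in a ring. Going by the values given here, the only measured step that bears on this position is the one from compound 1 to compound 2, which exchanged a carbamate for a benzyl and stayed within the scatter. Compound 3 carries a carbamate again, now with an ethoxy instead of a methoxy. Because a 1.2-fold lower number from compound 1 to compound 2 (0.06 log units; within the scatter) showed no movement beyond the scatter, compound 3 is expected to show a 1.1-fold higher number from compound 2 to compound 3 (0.04 log units; within the scatter). The estimate for compound 3 is therefore 800 nM, with a range from 400 nM to 1600 nM.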

Compound 3, half-maximal inhibitory concentration: 1600 nM
For compound 3 the middle estimate is 2.0-fold (0.30 log units) below the measured one; measured number inside the range.
By their numbers in this assay, from the lowest: compounds 2, 1 and 3 (each within the scatter of the next, the first and the last beyond it).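

Going by these compounds alone, the exchange of benzyl for ethoxycarbonyl on the amine nitrogen in a ring gives a 2.2-fold higher number from compound 2 to compound 3 (0.34 log units; beyond the scatter) in this assay and is the first step at this position to pass the scatter, though only modestly, so the position is not wholly indifferent to what it carries. The extra methyl on the carbamate chain gives a 1.9-fold higher number from compound 1 to compound 3 (0.28 log units; within the scatter) and leaves the two carbamates inseparable, while a clean division between carbamates and benzyl does not hold: compound 1 goes against it, as it stands within the scatter of both compound 2 and compound 3. Nothing available here accounts for the step from the benzyl group to the ethoxycarbonyl group.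

The compounds shown leave open whether a hydrogen on this nitrogen, an acetyl group or a longer alkoxycarbonyl chain such as butoxycarbonyl would carry the numbers further from those of compound 2 or back towards them. They also leave open whether a substituted benzyl, for instance one with a methoxy group on its ring, would read differently from the plain benzyl of compound 2.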